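Chloro for methoxy on the fused ring: permeability notes

A few compounds are considered here, and "the series" means these few. Any claim that something is new, unique, unknown or untested is made for them only; others in the source may bear on it.

Measured so far, in an ADME assay for permeability, using PAMPA, at pH 4; on this read-out lower numbers stand for lower permeability and higher numbers for higher permeability:
compound 1, `COc1ccc2[nH]c(C)c(Cc3ccccc3)c(=O)c2c1`: 167 10^-6 cm/s
compound 2, `Cc1[nH]c2ccc(Cl)cc2c(=O)c1Cc1ccccc1`: 422 10^-6 cm/s
compound 3, `COc1cccc2c(=O)c(Cc3ccccc3)c(C)[nH]c12`: 164 10^-6 cm/s

Compound 1 and compound 2 differ in one place, (chloro in place of methoxy on an aromatic carbon), and in this assay that change gave a 2.5-fold higher number from compound 1 to compound 2 (0.40 log units; beyond the scatter), a step beyond the scatter. Compound 3 shares its atoms with compound 1 but has them joined differently; the difference between the two cores is not broken down here. The readings of compound 3 and compound 1 in this assay lie within the scatter of each other, so nothing is made of their order.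

Compound 4, `Cc1[nH]c2c(Cl)cccc2c(=O)c1Cc1ccccc1`, carries the same kind of change relative to compound 3, namely (chloro in place of methoxy on an aromatic carbon). It is the same kind of change as from compound 1 to compound 2 and not the same: in the earlier pair the place is meta to a fused ring and para to a fused ring, whereas here it is ortho to a fused ring and meta to a fused ring.

The step expected in this assay is a 2.3-fold higher number from compound 3 to compound 4 (0.36 log units; beyond the scatter). This rests on the earlier step of a 2.5-fold higher number from compound 1 to compound 2 (0.40 log units; beyond the scatter) and on the reading of compound 3, 164 10^-6 cm/s, with a wider range allowed for the different place. Compound 4 is therefore estimated at 380 10^-6 cm/s, expected to fall between 200 10^-6 cm/s and 650 10^-6 cm/s.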

Compound 4, apparent permeability: 430 10^-6 cm/s
Beside the measured number, compound 4's estimate is 1.1-fold (0.05 log units) below it, within the range that was stated.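

In this assay, chloro in place of methoxy on an aromatic carbon gave a 2.6-fold higher number from compound 3 to compound 4 (0.42 log units; beyond the scatter), and this step matches the one seen earlier, so the change carries from one core to the other without a readable difference in size: the same change on two cores in this assay, a 2.5-fold higher number (0.40 log units; beyond the scatter) from compound 1 to compound 2 and a 2.6-fold higher number (0.42 log units; beyond the scatter) from compound 3 to compound 4, 1.0-fold (0.02 log units) apart, within the scatter of two such steps. The two pairs place the change differently, ortho to a fused ring and meta to a fused ring in one, meta to a fused ring and para to a fused ring in the other, yet the steps do not tell these two places apart. This agreement rests on two pairs and one read-out only; it does not show why the number rises, and it does not establish that the step would hold on any other core.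

The compounds shown leave open whether a different group in place of methoxy, such as fluoro, trifluoromethyl, an amine or a carboxylic acid, would give a step of similar size. Also open, going by these compounds, is whether the chloro step would survive with a further change elsewhere on the shared core, for example a longer chain or an amide.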